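The source may report more compounds than this note shows. Statements on the series, on what has been measured and on what is new or still open speak of the compounds shown alone.

Measured in an ADME assay on a cell-free system (plasma, Mus musculus) for protein binding, using equilibrium dialysis:
- compound 1 `Cc1nc(-c2cccc(CN(C)c3ccc4[nH]nc(C(=O)O)c4c3)c2)sc1C`: 99.9%
- compound 2 `CN(C)c1noc(-c2cccc(CN(C)c3ccc4[nH]nc(C(=O)O)c4c3)c2O)n1`: 99.9%
- compound 3 `CN(C)c1noc(-c2cccc(CNc3cnc4nn[nH]c4c3)c2O)n1`: 98.4%

Compound 2 at 99.9% is level with compound 1, and the two share the lowest unbound fraction of the three. Compound 3 at 98.4% leaves a larger unbound fraction, beyond the scatter.

Compound 4 `CC(C)c1csc(-c2cccc(CN(C)c3ccc4[nH]nc(C(=O)O)c4c3)c2O)n1` has 4-isopropyl-1,3-thiazol-2-yl in place of 3-(dimethylamino)-1,2,4-oxadiazol-5-yl, ortho to a hydroxy group: 4-isopropyl-1,3-thiazol-2-yl in place of 3-(dimethylamino)-1,2,4-oxadiazol-5-yl on an aromatic carbon. Within the data shown here, no measured pair isolates this change. With compound 1 and compound 2 level, no step beyond the scatter is expected in this assay. The expected step is no change at the digits printed from compound 2 to compound 4 (within the scatter). For compound 4 the estimate is 99.9%, with an expected range of 99.7% to 99.95%.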

Compound 4, plasma protein binding in the Mus musculus assay: > 99.9%
Compound 4: only a limit was reported; the forecaster's own chance of this, stated with the estimate: 15%; the middle value lies on the limit itself.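

In the Mus musculus assay compound 4 reads > 99.9%, which is a limit of the assay and not a number. Placing 4-isopropyl-1,3-thiazol-2-yl in place of 3-(dimethylamino)-1,2,4-oxadiazol-5-yl, ortho to a hydroxy group, gives an unbound fraction no higher from compound 2 to compound 4 (the limit leaves the size open), so this position shows no loss of binding with this change, though the size cannot be read: the limit of > 99.9% in the Mus musculus assay, at which 1 of the 4 values shown sits. In a physicochemical assay for solubility, measured as kinetic solubility, at pH 7.4 (a higher number here means a more soluble compound, a lower number a less soluble compound), compound 2 gives 135000 nM and compound 4 gives 6000 nM, so the same change does separate the pair, and this is the first measured step at this position: the measured solubility of compound 2, 135000 nM, and of compound 4, 6000 nM, a 23-fold lower number (1.35 log units; beyond the scatter)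

The compounds shown leave open how a morpholine or a primary amide in this place would read in the Mus musculus assay and in the physicochemical assay.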